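The source may hold more compounds than are shown below. What is called first, only, known or untested is meant among the compounds shown, and "the series" means these compounds.

Measured in an assay on HEK293 cells for displacement of a labelled ligand from Sigma non-opioid intracellular receptor 1 (Homo sapiens), read by scintillation counting, with a stated time of 120 min; a higher number here means a weaker inhibitor, a lower number a stronger inhibitor:
compound 2, `Fc1ccc(-c2ncnc3c2cnn3CCN2CCCCC2)cc1`, 95 nM
compound 1, `CNC1CCN(c2ncnc3c2cnn3CCN2CCCCC2)C1`, 25800 nM

For the measured compounds named here, compound 2 holds the lower of the two numbers in this assay; the one measured step, a 270-fold lower number from compound 1 to compound 2 (2.43 log units; beyond the scatter), is what separates them, and it is large. Compound 3 is `Cc1cc(F)ccc1-c1ncnc2c1cnn2CCN1CCCCC1`. It differs from compound 2 by methyl in place of hydrogen on an aromatic carbon. Going by the values given here, no measured step speaks to this kind of change: the single step above exchanges one whole group on the shared core for a quite different one, whereas here only a small group is added to the 4-fluorophenyl that compound 2 already carries. With nothing to point one way or the other, the step is expected to stay within the usual scatter, namely a 1.1-fold higher number from compound 2 to compound 3 (0.02 log units; within the scatter). Compound 3 is therefore estimated at 100 nM, with a range from 30 nM to 320 nM.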

Compound 3, inhibition constant: 48 nM
For compound 3 the middle estimate is 2.1-fold (0.32 log units) above the measured one, within the range that was stated.
By their numbers in this assay, from the lowest: compounds 3 and 2 (each within the scatter of the next); then compound 1.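

In this assay, placing a methyl group on an aromatic carbon, ortho to a large group and meta to the fluoro group, gives a 2.0-fold lower number from compound 2 to compound 3 (0.30 log units; within the scatter), so this position accepts the added carbon with no change that can be told from the scatter. Replacing 3-(methylamino)pyrrolidin-1-yl with 4-fluoro-2-methylphenyl gives a 540-fold lower number from compound 1 to compound 3 (2.73 log units; beyond the scatter), so the large step first seen with 4-fluorophenyl persists with the methyl in place. No available measurement bears on the reason for this result.

The compounds shown leave open whether an ethyl or methoxy group at this same place would fit as well, or whether a methyl group elsewhere on the ring would behave alike. They also leave open what a chloro group in place of the fluoro group would do.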